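From 2-chlorophenyl to 3-bromophenyl on the shared core

A few compounds are considered here, and "the series" means these few. Any claim that something is new, unique, unknown or untested is made for them only; others in the source may bear on it.

In a functional assay on U-251 cells (Homo sapiens) for antiproliferative activity, read by MTT assay, with a stated time of 24 h (on this read-out lower numbers stand for stronger inhibition and higher numbers for weaker inhibition), compound 1 `COc1cc(OC)c(-c2coc3cc(OCc4ccc(Cl)cc4)ccc3c2=O)cc1OC` gives 470 nM. Compound 2 `COc1cc(OC)c(-c2coc3cc(OCc4ccccc4Cl)ccc3c2=O)cc1OC` gives only a limit, > 10000 nM. Compound 3 `COc1cc(OC)c(-c2coc3cc(OCc4cccc(Br)c4)ccc3c2=O)cc1OC` carries 3-bromophenyl in place of the 2-chlorophenyl of compound 2, on a saturated chain carbon bound to an oxygen on an aromatic ring: 3-bromophenyl in place of 2-chlorophenyl on a saturated chain carbon bound to an oxygen on an aromatic ring. Among the measured compounds shown here, one measured step bears on this place, an at least 21-fold higher number from compound 1 to compound 2 (1.32 log units; beyond the scatter), which is large and beyond the scatter and brought in 2-chlorophenyl in place of 4-chlorophenyl. Since compound 3 gives up that 2-chlorophenyl, a sizeable step towards a lower number is expected in this assay, although compound 3 could also remain at the limit. The expected step is an at least 3.3-fold lower number from compound 2 to compound 3 (0.52 log units; beyond the scatter). Compound 3 is estimated at 3000 nM, with an expected range from 600 nM to 10000 nM.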

Compound 3, half-maximal inhibitory concentration: > 10000 nM
Compound 3 ended at the assay's limit (the forecaster's own chance of this, stated with the estimate: 35%); middle value at least 3.3-fold (0.52 log units) from the limit.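

In this assay, the 4-chlorophenyl of compound 1 has now been replaced by a second group at this place, and 3-bromophenyl brings an at least 21-fold higher number from compound 1 to compound 3 (1.32 log units; beyond the scatter). The large rise seen earlier, an at least 21-fold higher number from compound 1 to compound 2 (1.32 log units; beyond the scatter), is therefore not confined to 2-chlorophenyl: among the three compounds shown, only compound 1 gives a value that is not a limit. The step between 2-chlorophenyl and 3-bromophenyl cannot be read, because compound 2 and compound 3 both rest at a limit: the limit of > 10000 nM in this assay, at which 2 of the 3 values shown sit.

3-bromophenyl differs from 4-chlorophenyl in both its halogen and the number in its name, so the compounds shown do not separate these two changes. From the compounds shown here alone, what 4-bromophenyl or 3-chlorophenyl would give on the shared core remains open.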